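Swapping thiophen-2-yl for furan-2-yl: what to expect

This account rests on a few compounds, and the source may have more. Where it says the series, first, only, none or still open, it means among the compounds named here.

Measured so far in a functional assay on SH-SY5Y cells (Homo sapiens) for cytotoxicity, read by MTT assay, with a stated time of 72 h; a lower number here means a stronger inhibitor, a higher number a weaker inhibitor
- Compound 1 (`CCCC[S+]([O-])CCCCN=C=S`) gives 6470 nM
- Compound 2 (`[O-][S+](CCCCN=C=S)Cc1cccs1`) gives 5310 nM

Going by the values given here, only two numbers are available, and compound 2 stands level with compound 1. The gap between them lies within the usual scatter of repeated measurements, so the two cannot be told apart.

The next compound, compound 3 (`[O-][S+](CCCCN=C=S)Cc1ccco1`), has furan-2-yl in place of thiophen-2-yl on a saturated chain carbon bound to a sulfur. Counted out, the change reads (furan-2-yl in place of thiophen-2-yl on a saturated chain carbon bound to a sulfur) and it swaps one five-membered aromatic ring for another.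

Among the compounds with values here, no compound carrying furan-2-yl has been measured yet, so the only guide is the one measured step at this same place. That step is a 1.2-fold lower number from compound 1 to compound 2 (0.09 log units; within the scatter) and it stays within the scatter, even though propyl and thiophen-2-yl are quite different groups.

No step beyond the scatter is therefore expected in this assay for this swap, and the estimated step is a 1.0-fold higher number from compound 2 to compound 3 (0.02 log units; within the scatter) in size. For compound 3 the expected value is 5500 nM with an estimated range from 3000 nM to 10000 nM for the measurement.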

Compound 3, half-maximal inhibitory concentration: 7790 nM
The estimate for compound 3 lay 1.4-fold (0.15 log units) below the measured number, and the stated range covers the measured number.
By their numbers in this assay, from the lowest: compounds 2, 1 and 3 (each within the scatter of the next).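

In this assay, putting furan-2-yl in place of thiophen-2-yl on a saturated chain carbon bound to a sulfur gives a 1.5-fold higher number from compound 2 to compound 3 (0.17 log units; within the scatter) and so stays within the scatter, which means that a swap between two five-membered aromatic rings, one with oxygen and one with sulfur as its hetero atom, does not separate these compounds. Replacing propyl with furan-2-yl at the same place gives a 1.2-fold higher number from compound 1 to compound 3 (0.08 log units; within the scatter) and also stays within the scatter, so thiophen-2-yl is no longer the only ring that stands level with the open chain. No available measurement bears on why these numbers lie so close together.

The compounds shown leave open whether any group at this place can move the number beyond the scatter, such as an amine, a carboxylic acid or a much longer chain. The numbers shown all come from this assay so how propyl, thiophen-2-yl and furan-2-yl compare in another cell line also remains an open question.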